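The source may report more compounds than this note shows. Statements on the series, on what has been measured and on what is new or still open speak of the compounds shown alone.

Measured compounds in a functional assay on OVCAR-3 cells (Homo sapiens) for inhibition, read by MTT assay, with a stated time of 24 h; a higher number here means a weaker inhibitor, a lower number a stronger inhibitor:
- compound 1 `CC1(C)[C@H]2CC[C@]1(C)N(Cc1cn(-c3ccc(C#N)cc3)nn1)C(=O)C2` gives 380 nM
- compound 2 `CC1(C)[C@H]2CC[C@]1(C)N(Cc1cn(-c3cccc(F)c3)nn1)C(=O)C2` gives 430 nM
- compound 3 `COc1cccc(-n2cc(CN3C(=O)C[C@@H]4CC[C@@]3(C)C4(C)C)nn2)c1` gives 280 nM

The three share one core and differ only in the aryl group on the aromatic nitrogen of the triazole. Compound 3 has the lowest of the three numbers, but the steps of a 1.4-fold lower number from compound 1 to compound 3 (0.13 log units; within the scatter) and a 1.5-fold lower number from compound 2 to compound 3 (0.19 log units; within the scatter) are both within the scatter, so no order among the three can be claimed. The step of a 1.1-fold higher number from compound 1 to compound 2 (0.05 log units; within the scatter) likewise shows that exchanging one aryl substituent for another has so far left this assay essentially unchanged.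

Compound 4 `CC1(C)[C@H]2CC[C@]1(C)N(Cc1cn(-c3ccc(Br)cc3)nn1)C(=O)C2` is not yet measured. Its difference from compound 3: 4-bromophenyl in place of 3-methoxyphenyl on an aromatic nitrogen. Among the measured compounds shown here, no measured step involves a 4-bromophenyl group, so nothing bears on it directly; what does bear on it is that every aryl exchange seen so far, namely a 1.1-fold higher number from compound 1 to compound 2 (0.05 log units; within the scatter), a 1.4-fold lower number from compound 1 to compound 3 (0.13 log units; within the scatter) and a 1.5-fold lower number from compound 2 to compound 3 (0.19 log units; within the scatter), stayed within the scatter. The expectation is therefore a step of about a 1.3-fold higher number from compound 3 to compound 4 (0.10 log units; within the scatter), with no direction beyond the scatter.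

Compound 4 is estimated at 350 nM in this assay, with a range from 150 nM to 800 nM.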

Compound 4, half-maximal inhibitory concentration: 140 nM
Compound 4: the middle estimate sits 2.5-fold (0.40 log units) above what was measured; measured number below the stated range.
By their numbers in this assay, from the lowest: compounds 4, 3, 1 and 2 (each within the scatter of the next, the first and the last beyond it).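

In this assay, among the compounds shown here, the aryl group on the aromatic nitrogen of the triazole now shows a modest effect, since a 3.1-fold lower number from compound 2 to compound 4 (0.49 log units; beyond the scatter) and a 2.7-fold lower number from compound 1 to compound 4 (0.43 log units; beyond the scatter) are the first aryl exchanges at this position to lie beyond the scatter. The second of these steps is a single exchange of bromo for cyano on an aromatic carbon of the phenyl ring, so the identity of that substituent can move the number, while a 2.0-fold lower number from compound 3 to compound 4 (0.30 log units; within the scatter) stays within the scatter and leaves compound 4 not separable from compound 3. No measured evidence on the cause of these steps is available.

For the compounds shown here, the 4-bromophenyl group is the only bromo example here, so it remains open whether the shift belongs to bromine itself or would also appear with another halogen such as chloro or iodo, and whether moving bromo to the 3-position of the phenyl ring would keep it. Also open, from the compounds shown here alone, is how this position would respond to a phenyl ring carrying an amine or a carboxylic acid, or to a plain alkyl chain in place of the aryl group.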